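Swapping iodo for a fluorophenyl alkyne at the assay limit

The compounds below may be only part of what the source reports. "The series", "measured", "known", "first", "only" and "open" are said of these compounds alone.

Compound 1 `CCOC(=O)c1nnn([C@@H]2O[C@H](CO)[C@H]3OC(C)(C)O[C@H]32)c1I`: > 10000 nM, a limit
Compound 2 `COC(=O)c1nnn([C@@H]2O[C@H](CO)[C@H]3OC(C)(C)O[C@H]32)c1I`: > 10000 nM, a limit

In a functional assay on K562 cells (Homo sapiens), read by XTT assay, with a stated time of 48 h (a lower number here means a stronger inhibitor, a higher number a weaker inhibitor), compound 2 reads > 10000 nM, which is a limit and not a number. The same holds for compound 1, so the evidence is simply (the limit of > 10000 nM in this assay, at which 2 of the 2 values shown sit).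

Compound 3 `COC(=O)c1nnn([C@@H]2O[C@H](CO)[C@H]3OC(C)(C)O[C@H]32)c1C#Cc1ccc(F)cc1` is not yet measured. It changes compound 2 as follows: 2-(4-fluorophenyl)ethynyl in place of iodo on an aromatic carbon. The group 2-(4-fluorophenyl)ethynyl replaces iodo on an aromatic carbon, bringing in one six-membered aromatic ring of carbon only.

Among the compounds with values here, the one measured change is a step that the two limits leave unreadable from compound 1 to compound 2. It lies elsewhere in the molecule and offers no size to carry over. A small gain in this assay is expected, though compound 3 may well stay at the limit. The expected change is a number no higher from compound 2 to compound 3 (the limit leaves the size open). The estimate for compound 3 is 10000 nM, with an expected range of 3000 nM to 30000 nM.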

Compound 3, half-maximal inhibitory concentration: > 10000 nM
Compound 3 ended at the assay's limit; the forecaster's own chance of this, stated with the estimate: 65%; the middle value lies on the limit itself.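

In this assay compound 3 gives > 10000 nM, which is a limit and not a number. No step among compound 1, compound 2 and compound 3 can therefore be read: the limit of > 10000 nM in this assay, at which 3 of the 3 values shown sit.

The compounds shown leave open whether replacing iodo with 2-(4-fluorophenyl)ethynyl changes inhibitory strength at all.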